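Sulfonamide series: dimethylphenyl replacing bromophenyl on the sulfonyl

The compounds below may be only part of what the source reports. "The series", "measured", "known", "first", "only" and "open" are said of these compounds alone.

Measured so far:
compound 1, `CC1CCN(C2CCN(S(=O)(=O)c3cccc(Br)c3)CC2)CC1`, 3.2 nM
compound 2, `Cc1ccc(-c2cccc(S(=O)(=O)N3CCC(N4CCC(C)CC4)CC3)c2)cc1`, 11 nM
compound 3, `Cc1cc(C)cc(-c2cccc(S(=O)(=O)N3CCC(N4CCC(C)CC4)CC3)c2)c1`, 41 nM

In a functional assay on DLD-1 cells (Homo sapiens) for antiproliferative activity, read by CellTiter-Glo, with a stated time of 72 h (a lower number here means a stronger inhibitor, a higher number a weaker inhibitor), compound 1 gives the lowest number of the three, with compound 2 next and compound 3 furthest off. The two steps from it are a 3.4-fold higher number from compound 1 to compound 2 (0.54 log units; beyond the scatter) and a 13-fold higher number from compound 1 to compound 3 (1.11 log units; beyond the scatter); between the aryl pair the step is a 3.7-fold higher number from compound 2 to compound 3 (0.57 log units; beyond the scatter). Each replaces the bromo with a substituted phenyl and each raises the number.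

Compound 4, `Cc1ccc(S(=O)(=O)N2CCC(N3CCC(C)CC3)CC2)cc1C`, is not yet measured. Its change from compound 1 is 3,4-dimethylphenyl in place of 3-bromophenyl on a sulfonyl sulfur. This is not a direct parallel to the measured steps: no aryl is added, the ring on the sulfonyl keeps one ring and the bromo is exchanged for two methyls. The measured steps bear on it only in that every departure from the bromo so far has weakened compound 1; the size here is expected smaller than in those steps. A modest rise in this assay is expected, a 2.5-fold higher number from compound 1 to compound 4 (0.40 log units; beyond the scatter), with appreciable uncertainty. Compound 4 is estimated at 8 nM, range 2.5 nM to 30 nM.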

Compound 4, half-maximal inhibitory concentration: 24 nM
For compound 4 the middle estimate is 3.0-fold (0.48 log units) below the measured one, and the stated range covers the measured number.
By their numbers in this assay, from the lowest: compound 1; then compound 2; then compounds 4 and 3 (each within the scatter of the next).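

In this assay, exchanging 3-bromophenyl for 3,4-dimethylphenyl on the sulfonyl sulfur gives a 7.5-fold higher number from compound 1 to compound 4 (0.88 log units; beyond the scatter). The earlier steps shown here replaced bromo with a substituted phenyl, whereas here the group on the sulfur keeps one six-membered aromatic ring of carbon only, so the rise in the number does not require an added aryl ring. All three departures from the 3-bromophenyl of compound 1 now raise the number, and no measurement at hand explains this.

Compound 4 loses the bromine and gains two methyls in one step, which leaves the contribution of each unresolved. Also open, going by these compounds, is how 3-chlorophenyl or 3-methylphenyl on the sulfonyl sulfur would compare with the 3-bromophenyl of compound 1.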